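Methyl Beside the Bromine: One Change, Tested Twice

The compounds below may be only part of what the source reports. "The series", "measured", "known", "first", "only" and "open" are said of these compounds alone.

Compound 1 `O=C(CBr)Nc1cccc(C(=O)NC(=O)Nc2ccccc2)c1` in a functional assay on CCRF-CEM cells (Homo sapiens) for antiproliferative activity, read by MTT assay, with a stated time of 72 h; a lower number here means a stronger inhibitor, a higher number a weaker inhibitor: 5010 nM
Compound 2 `CC(Br)C(=O)Nc1cccc(C(=O)NC(=O)Nc2ccccc2)c1`: > 20000 nM (a limit of the assay, not a number)
Compound 3 `COc1cc(NC(=O)NC(=O)c2cccc(NC(=O)CBr)c2)cc(OC)c1OC`: 330 nM

Of the compounds shown here, three have been measured. Compound 1 and compound 2 share a core and differ in one place: methyl in place of hydrogen on a saturated chain carbon bound to a bromine atom and a carbonyl carbon. Compound 2 reaches only the assay limit, so its value is a limit and not a number. Still, the step of an at least 3.9-fold higher number from compound 1 to compound 2 (0.60 log units; beyond the scatter) tells that the methyl made the compound at least modestly weaker, and this rests on (the limit of > 20000 nM in this assay, at which 1 of the 3 values shown sits).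

Compound 3 carries a different core; how its core differs from that of compound 1 is not broken down here. Among the three, compound 3 gives the lowest number, and its nearest neighbour is compound 1, which stands a good way higher.

Compound 4 `COc1cc(NC(=O)NC(=O)c2cccc(NC(=O)C(C)Br)c2)cc(OC)c1OC` is not yet measured. It stands to compound 3 exactly as compound 2 stands to compound 1: methyl in place of hydrogen on a saturated chain carbon bound to a bromine atom and a carbonyl carbon. The two place descriptions are the same word for word, so this is the same change. Because the step of an at least 3.9-fold higher number from compound 1 to compound 2 (0.60 log units; beyond the scatter) weakened the earlier pair at least modestly, the same weakening is expected here, though only a floor is known for its size. For compound 4 in this assay a step of a 4.8-fold higher number from compound 3 to compound 4 (0.69 log units; beyond the scatter) is expected, landing the estimate at 1600 nM, somewhere between 500 nM and 6000 nM.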

Compound 4, half-maximal inhibitory concentration: 1330 nM
Compound 4: the middle estimate sits 1.2-fold (0.08 log units) above what was measured; the range from low to high includes it.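

In this assay, the methyl on the saturated chain carbon bound to a bromine atom and a carbonyl carbon gave a 4.0-fold higher number from compound 3 to compound 4 (0.61 log units; beyond the scatter), which means the change weakened the compound on this second core as well. Set beside the earlier pair, the change points the same way on both cores, but its size can be compared only in part: the same change on two cores in this assay, an at least 3.9-fold higher number (0.60 log units; beyond the scatter) from compound 1 to compound 2 and a 4.0-fold higher number (0.61 log units; beyond the scatter) from compound 3 to compound 4; the limit leaves it open whether they differ Compound 2 gives > 20000 nM, which is a limit of the assay and not a number; the two cores therefore agree in direction, and nothing here shows how the change would behave on any further core.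

The compounds shown leave open whether a longer chain, such as ethyl in place of the methyl on that same carbon, would weaken the compounds further, and whether chlorine in place of the bromine would give the same kind of step. Among the compounds shown here, also open is whether the methyl step would hold on a core carrying an amine or a carboxylic acid, since only two cores are available for comparison here.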